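The source may hold more compounds than are shown below. What is called first, only, known or untested is meant among the compounds shown, and "the series" means these compounds.

Measured compounds:
compound 1 `COc1ccc(-c2ccc3c(NCCCNCc4cccc(OC)c4O)ccnc3c2)cc1`: 32000 nM
compound 2 `COc1ccc(Oc2ccc3c(NCCCNCc4cc(F)ccc4OC)ccnc3c2)cc1`: 14500 nM
compound 3 `COc1ccc(-c2ccc3c(NCCCNCc4ccco4)ccnc3c2)cc1`: 32000 nM

In a physicochemical assay for solubility, with a stated time of 18 h, at pH 7.4 (on this read-out lower numbers stand for lower solubility and higher numbers for higher solubility), compound 1 stands level with compound 3, and together they give the highest of the three numbers; compound 2 lies furthest from compound 1, with a lower number. The step of no change at the digits printed from compound 1 to compound 3 (within the scatter) shows that changing the group on the chain carbon bound to the amine nitrogen left the number untouched. Compound 4 `COc1cccc(CNCCCNc2ccnc3cc(Oc4ccc(F)cc4)ccc23)c1O` differs from compound 1 at another place: 4-fluorophenoxy in place of 4-methoxyphenyl on an aromatic carbon. Among the measured compounds shown here, no measured step alters this position alone. Compound 2 also carries an aromatic ring joined through oxygen, yet its side chain differs too, so its lower number is only a loose guide; a modest drop is expected, a 1.6-fold lower number from compound 1 to compound 4 (0.20 log units; within the scatter). Compound 4 is therefore estimated at 20000 nM, with a range from 8000 nM to 50000 nM.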

Compound 4, solubility: 14500 nM
For compound 4 the middle estimate is 1.4-fold (0.14 log units) above the measured one; the range from low to high includes it.
By their numbers in this assay, from the lowest: compounds 2 and 4 (each within the scatter of the next); then compounds 1 and 3 (each within the scatter of the next).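

In this assay, placing 4-fluorophenoxy on this aromatic carbon in place of 4-methoxyphenyl gives a 2.2-fold lower number from compound 1 to compound 4 (0.34 log units; beyond the scatter) and shows that this position can shift the number. Unlike no change at the digits printed from compound 1 to compound 3 (within the scatter) on the side chain, this modest step lies beyond the scatter. Nothing available here accounts for the step. From the compounds shown here alone, the swap changes the oxygen link and the fluorine together, so the part played by each stays open. A 4-fluorophenyl group at this place would separate the two, and an amine such as morpholine would test a very different kind of group there.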